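The source may report more compounds than this note shows. Statements on the series, on what has been measured and on what is new or still open speak of the compounds shown alone.

In a functional assay on KB cells (Homo sapiens) for antiproliferative activity, read by sulforhodamine B assay, with a stated time of 72 h (on this read-out lower numbers stand for stronger inhibition of growth and higher numbers for weaker inhibition of growth), two members of this series have been measured, and neither gave a number. Compound 1 `CCc1oc2c(C)c(OCc3cccc(C(F)(F)F)c3)ccc2c(=O)c1Br` gives > 22600 nM in this assay, which is a limit of the assay rather than a measured value. Compound 2 `CCc1cc(=O)c2ccc(OC)c(CBr)c2o1` gives > 33600 nM in this assay, again only a limit. Compound 2 therefore stands at one of the two limits shown, as described in the limit of > 33600 nM in this assay, at which 1 of the 2 values shown sits, while compound 1 sits at the other, (the limit of > 22600 nM in this assay, at which 1 of the 2 values shown sits). Among the compounds with values here, no two measured compounds differ in a single place, so no measured step exists to lean on. Compound 3 `CCc1cc(=O)c2ccc(OC(C)C)c(CBr)c2o1` differs from compound 2 by isopropyl in place of methyl on an oxygen on an aromatic ring. The step from compound 2 to compound 3 is expected to be a step that the limit leaves unreadable from compound 2 to compound 3, none beyond the usual scatter, since compound 2 already rests at a limit. Compound 3 is accordingly estimated at 40000 nM, within 15000 nM to 100000 nM, most likely reported again as a limit.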

Compound 3, concentration for 50% growth inhibition: > 30700 nM
Compound 3: only a limit was reported; the forecaster's own chance of this, stated with the estimate: 80%; the middle value is on the limit's open side.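

Compound 2 and compound 3 both rest at limits in this assay, so the change from methoxy to isopropoxy gives no readable step. The compounds shown leave open whether any member of this series reaches a measured value, and what size this change has.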